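The source may hold more compounds than are shown below. What is called first, only, known or untested is meant among the compounds shown, and "the series" means these compounds.

In a functional assay on SW480 cells (Homo sapiens) for inhibition, read by luminescence and resazurin assay, with a stated time of 3 days (on this read-out lower numbers stand for stronger inhibition and higher numbers for weaker inhibition), compound 3 `CCCNc1nc(NCc2ccc(C(=O)N3CCC(C(=O)NCc4ccc(F)cc4)CC3)cc2)c2ccccc2n1` gives 5700 nM, the highest of the three numbers recorded. Compound 1 `CCCNc1nc(NCc2ccc(C(=O)N3CCC(C(=O)NCc4ccc(F)cc4)CC3)cc2)c2cc(C)ccc2n1` gives 5200 nM in this assay, and the step of a 1.1-fold higher number from compound 1 to compound 3 (0.04 log units; within the scatter) is within the scatter. Compound 2 `CNc1nc(NCc2ccc(NC(=O)c3ccc(F)cc3)cc2)c2ccccc2n1` gives 2000 nM in this assay, the lowest value of the three. Compound 4 `CN(C)c1nc(NCc2ccc(C(=O)N3CCC(C(=O)NCc4ccc(F)cc4)CC3)cc2)c2ccccc2n1` has not been measured; it differs from compound 3 by dimethylamino in place of propylamino on an aromatic carbon. Going by the values given here, no measured step alters the group on that carbon, so the only guide is that the one recorded step, a 1.1-fold higher number from compound 1 to compound 3 (0.04 log units; within the scatter), was small. For compound 4 the expected step of no change at the digits printed from compound 3 to compound 4 (within the scatter) is none beyond the scatter, and compound 4 is therefore estimated at 5700 nM in this assay, within a range from 2500 nM to 13000 nM.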

Compound 4, half-maximal inhibitory concentration: 5500 nM
Estimate against measurement, compound 4: 1.0-fold (0.02 log units) above, and the stated range covers the measured number.
By their numbers in this assay, from the lowest: compound 2; then compounds 1, 4 and 3 (each within the scatter of the next).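

At the carbon between two ring nitrogen atoms, the step of a 1.0-fold lower number from compound 3 to compound 4 (0.02 log units; within the scatter) shows that in this assay dimethylamino can take the place of propylamino without a change beyond the scatter. This swap also removes the hydrogen-bond donor counted on propylamino, so that donor is not needed to hold the number at this level on this core. Nothing measured here explains the result. As far as these compounds go, it remains open whether a longer chain, a morpholine ring or a carboxylic acid at this carbon would move the number beyond the scatter.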